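Swapping Chloro for Methoxy on an Antiproliferative Series

This account rests on a few compounds, and the source may have more. Where it says the series, first, only, none or still open, it means among the compounds named here.

compound 1 `Cc1ccc2nc(NC(c3cn(-c4ccccc4)nc3-c3cccc([N+](=O)[O-])c3)c3c(O)ccc4ccccc34)sc2c1`: 38400 nM
compound 2 `Cc1ccc2nc(NC(c3cn(-c4ccccc4)nc3-c3cccc(Cl)c3)c3c(O)ccc4ccccc34)sc2c1`: 49700 nM
compound 3 `COc1ccc2nc(NC(c3cn(-c4ccccc4)nc3-c3ccc(Cl)cc3)c3c(O)ccc4ccccc34)sc2c1`: 23700 nM

All three values come from a functional assay on MCF7 cells (Homo sapiens) for antiproliferative activity, read by MTT assay, with a stated time of 48 h; a higher number here means a weaker inhibitor, a lower number a stronger inhibitor. Compound 3 lies within the scatter of compound 1 and beyond the scatter of compound 2, whose number is higher. Compound 4 `COc1ccc(-c2nn(-c3ccccc3)cc2C(Nc2nc3ccc(OC)cc3s2)c2c(O)ccc3ccccc23)cc1` keeps everything in compound 3 except one group, 4-chlorophenyl to 4-methoxyphenyl: methoxy in place of chloro on an aromatic carbon. Among the compounds with values here, only one measured step bears on this, a different swap on an aromatic carbon, chloro in place of nitro: a 1.3-fold higher number from compound 1 to compound 2 (0.11 log units; within the scatter). Within the data shown here, that step stayed within the scatter, and no measured step brings in methoxy, so the evidence is thin. The expected step in this assay is a 1.1-fold higher number from compound 3 to compound 4 (0.02 log units; within the scatter), which means none beyond the scatter is expected. Compound 4 is estimated at 25000 nM, with an expected range of 11000 nM to 55000 nM.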

Compound 4, half-maximal inhibitory concentration: 41800 nM
For compound 4 the middle estimate is 1.7-fold (0.22 log units) below the measured one; low and high end bracket the measured number.
By their numbers in this assay, from the lowest: compounds 3, 1, 4 and 2 (each within the scatter of the next, the first and the last beyond it).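

Within this assay the swap of 4-chlorophenyl to 4-methoxyphenyl gives a 1.8-fold higher number from compound 3 to compound 4 (0.25 log units; within the scatter) and so offers the first measured look at this site, where methoxy, with its hydrogen-bond acceptor, leaves the number inside the scatter. Nothing shown here gives a reason for this result.

Going by these compounds, whether an amine or a carboxylic acid on this same aromatic carbon would also stay within the scatter remains open. So does whether this swap would read the same on the methyl-bearing core of compound 1.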